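The source may hold more compounds than are shown below. What is called first, only, known or untested is meant among the compounds shown, and "the series" means these compounds.

Working notes on the series. Two compounds of the shared core carry numbers in a functional assay on A549 cells (Homo sapiens) for cytotoxicity, read by MTT assay, with a stated time of 72 h (a lower number here means a stronger inhibitor, a higher number a weaker inhibitor), so far. Compound 1 `COc1cc2c(Oc3ccc(NC(=O)c4nnn(-c5ccccc5)c4C)cc3F)ccnc2cc1OCCCN1CCCC1` gives 90 nM in this assay. Compound 2 `COc1cc2c(Oc3ccc(NC(=O)c4nnn(-c5ccc(F)cc5)c4C(F)(F)F)cc3F)ccnc2cc1OCCCN1CCCC1` gives 80 nM in this assay, the lower of the two numbers, though compound 1 sits only a little above it and the gap is within the scatter, so no order between the two can be claimed. Among the measured compounds shown here, compound 1 and compound 2 differ in more than one place, and no single step between them can be read.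

Compound 3 `COc1cc2c(Oc3ccc(NC(=O)c4nnn(-c5ccc(C)cc5)c4C(F)(F)F)cc3F)ccnc2cc1OCCCN1CCCC1` is not yet measured. It differs from compound 2 in one place: methyl in place of fluoro on an aromatic carbon of the six-membered aromatic ring of carbon only. Nothing measured in the series isolates this change, so no step beyond the scatter is expected in either direction, and compound 3 is expected to give about 90 nM in this assay, with a range of 40 nM to 220 nM. The step this estimate implies is a 1.1-fold higher number from compound 2 to compound 3 (0.05 log units; within the scatter) and is expected to stay within the scatter.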

Compound 3, half-maximal inhibitory concentration: 370 nM
For compound 3 the middle estimate is 4.1-fold (0.61 log units) below the measured one; measured number outside the range, above it.
By their numbers in this assay, from the lowest: compounds 2 and 1 (each within the scatter of the next); then compound 3.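

In this assay, among the compounds shown here, the change from 4-fluorophenyl to 4-methylphenyl gives the first step that can be read, a 4.6-fold higher number from compound 2 to compound 3 (0.67 log units; beyond the scatter). This position, para to a large group, is therefore not indifferent to its substituent: exchanging one heavy atom for one heavy atom, with no hydrogen-bond donor, acceptor or net charge entering or leaving, moves the number beyond the scatter. Of the two groups, fluoro goes with the lower number, with the trifluoromethyl group unchanged in both compounds, and no measurement bears on the reason for this step.

The compounds shown leave open how a chloro or a methoxy group would read at this position, and whether the fluoro-to-methyl step would keep its size in a compound without the trifluoromethyl group. Compound 1 differs from compound 2 and from compound 3 in more than one place, so neither of those steps can be read.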